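The source may report more compounds than this note shows. Statements on the series, on what has been measured and on what is new or still open speak of the compounds shown alone.

For the measured compounds named here, compound 1, with the structure `Cc1cc(C)n(-c2nc(C(F)(F)F)cc(=O)[nH]2)n1`, is the only member of this small set for which a number exists in an ADME assay on CHO cells (Cricetulus griseus) for cytotoxicity, read by MTT assay; on this read-out higher numbers stand for weaker inhibition and lower numbers for stronger inhibition: compound 1 gives 150000 nM. Compound 2, `Cc1cc(C)n(-c2nc(-c3ccncc3)cc(=O)[nH]2)n1`, reaches only a limit in this assay, > 50000 nM. Compound 3, `Cc1cc(C)n(-c2nc(-c3cccnc3)cc(=O)[nH]2)n1`, likewise stops at a limit, > 50000 nM. Consequently the step that the limit leaves unreadable from compound 1 to compound 2 cannot be read, nor can a step that the limit leaves unreadable from compound 1 to compound 3, and the step that the two limits leave unreadable from compound 2 to compound 3 is hidden by two limits at once; the reason is simply (the limit of > 50000 nM in this assay, at which 2 of the 3 values shown sit).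

Compound 4, `Cc1cc(-c2ccccc2)n(-c2nc(C(F)(F)F)cc(=O)[nH]2)n1`, differs from compound 1 in one place: phenyl in place of methyl on an aromatic carbon. Going by the values given here, none of the measured steps touches this position; all three concern the group on the other aromatic carbon, and none of them could be sized. So the expectation for compound 4 rests only on compound 1 and on the observation that every change so far left the compounds weak in this assay. The step of a 1.5-fold lower number from compound 1 to compound 4 (0.18 log units; within the scatter) is therefore expected to stay within the ordinary scatter. Compound 4 is expected to give roughly 100000 nM in this assay, with a plausible range from 30000 nM to 300000 nM, and a fair chance that only a limit is reported.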

Compound 4, half-maximal inhibitory concentration: > 50000 nM
Compound 4: only a limit was reported; the forecaster's own chance of this, stated with the estimate: 40%; the middle value is on the limit's open side.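

Compound 4 also stops at a limit in this assay, so no new step can be read between compound 1 and compound 4, and the reason is simply: (the limit of > 50000 nM in this assay, at which 3 of the 4 values shown sit). The compounds shown leave open how large the effect of phenyl in place of methyl is in this assay, and whether it differs in size from that of either pyridinyl group in place of trifluoromethyl.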